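The source may report more compounds than this note shows. Statements on the series, on what has been measured and on what is new or still open speak of the compounds shown alone.

Compound 1 `O=C(NCCNS(=O)(=O)c1ccc(-c2ccccc2OCc2cccc(O)c2)s1)Nc1cc(Cl)cc(Cl)c1` gives > 50000 nM in a functional assay on RS4-11 cells (Homo sapiens) for inhibition, read by CCK-8 assay, with a stated time of 48 h (on this read-out lower numbers stand for stronger inhibition and higher numbers for weaker inhibition), which is a limit of the assay and not a number. Among the compounds with values here, compound 2 `O=[N+]([O-])c1cccc(NC(=S)NCCNS(=O)(=O)c2ccc(-c3ccccc3OCc3cccc(O)c3)s2)c1` gives 9800 nM, the only true number so far. Within the data shown here, the one measured step, an at least 5.1-fold lower number from compound 1 to compound 2 (0.70 log units; beyond the scatter), lies beyond the scatter. Compound 3 `Cc1cc(C)cc(NC(=O)NCCNS(=O)(=O)c2ccc(-c3ccccc3OCc3cccc(O)c3)s2)c1` departs from compound 2 as follows: a group of 11 heavy atoms (9 carbon, 1 nitrogen, 1 oxygen; one six-membered aromatic ring of carbon only) in place of a group of 12 heavy atoms (7 carbon, 2 nitrogen, 2 oxygen, 1 sulfur; one six-membered aromatic ring of carbon only), on an amine nitrogen. Its (3,5-dimethylphenyl)carbamoyl group is a carbamoyl group, as on compound 1, so that step bears on it, read partly in reverse. A higher number is therefore expected in this assay, and the expected change is a 2.6-fold higher number from compound 2 to compound 3 (0.41 log units; beyond the scatter). For compound 3 the estimate is 25000 nM, with an expected range of 9000 nM to 60000 nM.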

Compound 3, half-maximal inhibitory concentration: 5800 nM
Beside the measured number, compound 3's estimate is 4.3-fold (0.63 log units) above it; the whole stated range lies above it.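

In this assay, 3,5-dimethylphenyl in place of 3,5-dichlorophenyl on an amide-type nitrogen gives an at least 8.6-fold lower number from compound 1 to compound 3 (0.93 log units; beyond the scatter), so the two substituents on this ring alone separate a measurable compound from an unmeasurable one. The (3,5-dimethylphenyl)carbamoyl group and the group it replaces on the amine nitrogen give a 1.7-fold lower number from compound 2 to compound 3 (0.23 log units; within the scatter), so the two are not told apart here. The true size of the first step remains unknown, as compound 1 stands at a limit and not a number: the limit of > 50000 nM in this assay, at which 1 of the 3 values shown sits.

From the compounds shown here alone, whether a methoxyphenyl or an aminophenyl group on this nitrogen would lower the number further remains open.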